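Dimethylamino for chloro on a fused pyridine core

The compounds below may be only part of what the source reports. "The series", "measured", "known", "first", "only" and "open" are said of these compounds alone.

Measured compounds:
compound 1, `Clc1[nH]ccc2ncnc1-2`, < 5% in a functional assay on EL4 cells (Mus musculus) for inhibition, tested at 100 uM; on this read-out higher numbers stand for more inhibition at the one concentration tested (going by the name of the read-out) and lower numbers for less inhibition;
compound 2, `OC[C@H]1OC(n2cnc3c(Cl)nccc32)[C@H](O)[C@@H]1O`, < 5% in this assay;
compound 3, `CN(C)c1[nH]ccc2ncnc1-2`, 25% in this assay.

The value of compound 1 in this assay is a limit of the assay, not a number. The value of compound 2 in this assay is likewise a limit. Compound 2 stands at the limit of < 5% in this assay, at which 2 of the 3 values shown sit, so only a range is known for it. Within the data shown here, compound 3 is the one measured compound with a number in this assay.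

Compound 1 and compound 3 share a core and differ in one place: dimethylamino in place of chloro on an aromatic carbon. That change gave a number at least 20 percentage points higher from compound 1 to compound 3 (beyond the scatter).

Compound 2 carries the same chloro group on a core bearing a sugar; how the core of compound 2 differs from the core of compound 1 is not broken down here. Compound 4, `CN(C)c1nccc2c1ncn2C1O[C@H](CO)[C@@H](O)[C@H]1O`, is not yet measured in this assay. It stands to compound 2 as compound 3 stands to compound 1, by the same change: dimethylamino in place of chloro on an aromatic carbon. The place is the same in both pairs.

Among the measured compounds shown here, from the only measured instance of this change, a number at least 20 percentage points higher from compound 1 to compound 3 (beyond the scatter), the author expects a step of a number at least 13 percentage points higher from compound 2 to compound 4 (beyond the scatter). Compound 2 being at a limit leaves the starting point uncertain, so the result may again be reported only as a limit. For compound 4 in this assay the author estimates 18%, between 5% and 35%.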

Compound 4, a percentage reported as inhibition, at one concentration (the size of the read-out at that concentration, not a potency): 10%
Compound 4: the middle estimate sits 8 percentage points above what was measured; low and high end bracket the measured number.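

In this assay, dimethylamino in place of chloro on the core bearing the sugar gives a number at least 5 percentage points higher from compound 2 to compound 4 (that floor lies within the scatter), so this pair does not go against the rise seen on the core without the sugar, but on its own it does not establish a rise either. Set side by side, the two pairs show the same change tried on two cores, and they do not settle whether it carries over with the same size: the same change on two cores in this assay, a number at least 20 percentage points higher (beyond the scatter) from compound 1 to compound 3 and a number at least 5 percentage points higher (that floor lies within the scatter) from compound 2 to compound 4; the limit leaves it open whether they differ. Going by these compounds, neither pair starts from a number, so each step is a floor and not a measured size, and the true value of either chloro compound remains unknown: the limit of < 5% in this assay, at which 2 of the 4 values shown sit.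

The compounds shown leave open whether another amine on the same aromatic carbon, such as a pyrrolidine, a morpholine or a longer-chained dialkylamine, would follow dimethylamino on either core, and whether a non-amine group such as methoxy would do the same. They also leave open how the change would behave on a core carrying something other than the sugar, such as a short hydroxyalkyl chain, and so whether any of this extends beyond these two cores.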